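5-HT6 sulfone series: amide to methylurea on the aminomethyl

The compounds below may be only part of what the source reports. "The series", "measured", "known", "first", "only" and "open" are said of these compounds alone.

Measured so far:
compound 1, `CS(=O)(=O)c1cccc(S(=O)(=O)c2ccc3c(c2)CCC[C@H]3CN)c1`: 3.98 nM
compound 2, `O=C(NC[C@@H]1CCCc2cc(S(=O)(=O)c3cccc(F)c3)ccc21)c1ncc[nH]1`: 15.9 nM

Two compounds carry the shared core with a sulfonyl-linked aryl ring. In an assay on isolated protein for displacement of a labelled ligand from 5-hydroxytryptamine receptor 6 (Homo sapiens) (on this read-out lower numbers stand for stronger inhibition and higher numbers for weaker inhibition), compound 1 gives 3.98 nM and compound 2 gives 15.9 nM. Compound 2 therefore stands at the higher of the two numbers, the gap to compound 1 lying beyond the scatter of repeated measurements.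

Compound 3, `CN(C[C@@H]1CCCc2cc(S(=O)(=O)c3cccc(F)c3)ccc21)C(N)=O`, has not been measured. It differs from compound 2 in one place: carbamoyl(methyl)amino in place of ((1H-imidazol-2-yl)carbonyl)amino on a saturated chain carbon bound to a saturated ring carbon. The heterocyclic acyl group on the chain nitrogen is thus exchanged for a small urea, the chain nitrogen now also carrying a methyl group.

Within the data shown here, no measured pair shows this kind of exchange, so the direction of the step rests only on the two values at hand. The expectation is a modest rise in this assay for compound 3, a step of a 1.6-fold higher number from compound 2 to compound 3 (0.20 log units; within the scatter) that may well stay within the scatter. Compound 3 is accordingly estimated at 25 nM, in a range from 8 nM to 80 nM.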

Compound 3, inhibition constant: 39.8 nM
Estimate against measurement, compound 3: 1.6-fold (0.20 log units) below; the measured number falls inside the stated range.
By their numbers in this assay, from the lowest: compound 1; then compound 2; then compound 3.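

In this assay, this position on a saturated chain carbon bound to a saturated ring carbon now has its first reading across a single-place change: carbamoyl(methyl)amino in place of ((1H-imidazol-2-yl)carbonyl)amino gives a 2.5-fold higher number from compound 2 to compound 3 (0.40 log units; beyond the scatter). The group on the chain is therefore not neutral for this read-out, although the step is modest and a group with no ring still leaves compound 3 at 39.8 nM, so the five-membered aromatic ring is not required for a measurable nanomolar value. No measurement at hand bears on what lies behind this step.

The exchange removes the five-membered aromatic ring and adds a methyl group on the chain nitrogen in a single step, so the share of each change in the shift cannot be separated from these compounds. Going by these compounds, an acetyl group or a methanesulfonyl group on the chain nitrogen, and a urea without the methyl group, remain open as ways of telling these contributions apart.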